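The source may report more compounds than this note shows. Statements on the series, on what has been measured and on what is new or still open speak of the compounds shown alone.

Working notes on the series.

Among the compounds with values here, compound 2 `CCOC(=O)Nc1ccc(S(=O)(=O)N2C(=O)N[C@@H](c3ccccc3)C2C)cc1Cl` carries an ethoxycarbonyl amide and a chloro substituent; in a functional assay on HCT-116 cells (Homo sapiens) for cytotoxicity, read by MTT assay (on this read-out higher numbers stand for weaker inhibition and lower numbers for stronger inhibition), compound 2 gives 5500 nM, the only number among the values shown. Compound 3 `CC1[C@H](c2ccccc2)NC(=O)N1S(=O)(=O)c1ccc(NC(=O)c2ccc(N)cc2)c(Cl)c1` differs from compound 2 by ethoxy in place of 4-aminophenyl on a carbonyl carbon. In this assay compound 3 reaches only the limit > 10000 nM. This gives the step of an at least 1.8-fold higher number from compound 2 to compound 3 (0.25 log units; that floor lies within the scatter). Compound 1 `Cc1cc(S(=O)(=O)N2C(=O)N[C@@H](c3ccccc3)C2C)ccc1NC(=O)c1ccc(N)cc1` differs from compound 3 by methyl in place of chloro on an aromatic carbon. In this assay compound 1 also reaches only the limit > 10000 nM. Both limits sit at the limit of > 10000 nM in this assay, at which 2 of the 3 values shown sit, so the step that the two limits leave unreadable from compound 3 to compound 1 cannot be sized.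

Compound 4 `CCOC(=O)Nc1ccc(S(=O)(=O)N2C(=O)N[C@@H](c3ccccc3)C2C)cc1C` is not yet measured. It differs from compound 2 by methyl in place of chloro on an aromatic carbon. This is the same kind of change as that from compound 3 to compound 1, but the place differs: in compound 4 the methyl is ortho to a (ethoxycarbonyl)amino group, whereas in compound 1 it is ortho to a ((4-aminophenyl)carbonyl)amino group. Since the measured step is unreadable, the expectation for compound 4 rests on compound 2 alone, with 5500 nM as the anchor, and the step from compound 2 to compound 4 is expected to be a 1.3-fold higher number from compound 2 to compound 4 (0.10 log units; within the scatter). Compound 4 is therefore estimated at 7000 nM, between 3000 nM and 16000 nM.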

Compound 4, half-maximal inhibitory concentration: 5500 nM
Estimate against measurement, compound 4: 1.3-fold (0.10 log units) above; the range from low to high includes it.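

In this assay, methyl in place of chloro on the aromatic carbon with ethoxy on the carbonyl carbon gives no change at the digits printed from compound 2 to compound 4 (within the scatter), and ethoxy in place of 4-aminophenyl with methyl on the ring gives an at least 1.8-fold lower number from compound 1 to compound 4 (0.25 log units; that floor lies within the scatter). The change to 4-aminophenyl on a carbonyl carbon can thus be set side by side on the chloro and the methyl core: the same change on two cores in this assay, an at least 1.8-fold higher number (0.25 log units; that floor lies within the scatter) from compound 2 to compound 3 and an at least 1.8-fold higher number (0.25 log units; that floor lies within the scatter) from compound 4 to compound 1; the limit leaves it open whether they differ. This shows that both cores are compatible with a similar outcome, but not that the change carries over with the same size, since each step is only a floor within the scatter, and the step from chloro to methyl with 4-aminophenyl on the carbonyl carbon cannot be read: the limit of > 10000 nM in this assay, at which 2 of the 4 values shown sit.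

Going by these compounds, it remains open how a methoxy group or a nitrile would compare with chloro and methyl on that aromatic carbon. On these data alone, it also remains open whether a longer alkoxy chain or a simple amine on the carbonyl carbon would give a number that can be read in this assay.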